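The compounds below may be only part of what the source reports. "The series", "measured", "known", "first", "only" and "open" are said of these compounds alone.

Compound 3, `CCCC(=O)N1CCC(CN(C2Cc3cc(C#N)ccc3N(Cc3cncn3C)C2)S(=O)(=O)c2ccccn2)CC1`, is one of three analogues sharing a core and differing only in the group on the ring nitrogen of the piperidine. In an ADME assay on Caco-2 cells (Homo sapiens) for permeability, in the apical to basolateral direction (a lower number here means that the compound crosses the layer more slowly, a higher number that the compound crosses the layer faster), compound 3 gives 0.5 10^-6 cm/s, level with compound 1, `Cn1cncc1CN1CC(N(CC2CCN(C(=O)CNC(=O)OC(C)(C)C)CC2)S(=O)(=O)c2ccccn2)Cc2cc(C#N)ccc21`, which gives 0.5 10^-6 cm/s; together these are the highest of the three numbers. Compound 2, `CC(C)S(=O)(=O)N1CCC(CN(C2Cc3cc(C#N)ccc3N(Cc3cncn3C)C2)S(=O)(=O)c2ccccn2)CC1`, gives 0.1 10^-6 cm/s, the lowest, and a 5.0-fold higher number from compound 2 to compound 3 (0.70 log units; beyond the scatter). Compound 4, `Cn1cncc1CN1CC(N(CC2CCN(C(=O)c3cccs3)CC2)S(=O)(=O)c2ccccn2)Cc2cc(C#N)ccc21`, is unmeasured; it differs from compound 3 by thiophen-2-yl in place of propyl on a carbonyl carbon. For the measured compounds named here, two measured steps bear on this. The closest is no change at the digits printed from compound 1 to compound 3 (within the scatter), a change on the same carbonyl carbon that did not move the number. The larger step, a 5.0-fold lower number from compound 1 to compound 2 (0.70 log units; beyond the scatter), replaced the whole carbonyl group with a sulfonyl, a deeper change than the present one, which keeps the carbonyl in place. On this basis the expected step for compound 4 is small, no change at the digits printed from compound 3 to compound 4 (within the scatter), in no direction clearly beyond the scatter. Compound 4 is therefore estimated at 0.5 10^-6 cm/s, with a range from 0.2 10^-6 cm/s to 1.2 10^-6 cm/s.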

Compound 4, apparent permeability: 0.5 10^-6 cm/s
Compound 4: the middle estimate sits on the measured number at the digits printed; the range from low to high includes it.
By their numbers in this assay, from the lowest: compound 2; then compounds 1, 3 and 4 (each within the scatter of the next).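

In this assay, the carbonyl carbon accepts a five-membered aromatic ring in place of an open chain: thiophen-2-yl for propyl gives (no change at the digits printed from compound 3 to compound 4 (within the scatter)). Thiophen-2-yl in place of ((tert-butoxycarbonyl)amino)methyl likewise gives (no change at the digits printed from compound 1 to compound 4 (within the scatter)), so three quite different groups on this carbonyl carbon now stand level, an aromatic ring among them. Isopropylsulfonyl on the ring nitrogen remains the one group that goes against this, since (thiophen-2-yl)carbonyl in its place gives (a 5.0-fold higher number from compound 2 to compound 4 (0.70 log units; beyond the scatter)), the same step that propylcarbonyl gave.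

From the compounds shown here alone, whether an amine, a carboxylic acid or a longer chain on this carbonyl carbon would leave the number where it stands remains open. Nothing at hand accounts for the level numbers among these carbonyl groups or for the gap to the sulfonyl.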